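From furan-2-yl to 5-fluoro-2-methoxyphenyl in compound 4

A few compounds are considered here, and "the series" means these few. Any claim that something is new, unique, unknown or untested is made for them only; others in the source may bear on it.

Measured so far in an ADME assay on HepG2 cells (Homo sapiens) for cytotoxicity, read by luminescence, CellTiter-Glo and ATP content, with a stated time of 72 h; a higher number here means that more compound is needed for the effect, a lower number that less compound is needed (values in brackets):
- compound 1 `FC(F)(F)c1cc(-c2ccc3c(NCCCNCc4ccco4)ccnc3c2)cc(C(F)(F)F)c1` (2410 nM)
- compound 2 `COc1cccc(CNCCCNc2ccnc3cc(Oc4ccc(F)cc4)ccc23)c1O` (11000 nM)
- compound 3 `COc1ccc(F)cc1CNCCCNc1ccnc2cc(-c3ccccc3)ccc12` (2960 nM)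

Compound 1 stands level with compound 3, the two lying within the scatter of each other, while compound 2 shows a higher number than compound 1, beyond the scatter. Compound 4 `COc1ccc(F)cc1CNCCCNc1ccnc2cc(-c3cc(C(F)(F)F)cc(C(F)(F)F)c3)ccc12` has not yet been measured. It keeps the core of compound 1 and exchanges one group on a saturated chain carbon bound to an amine nitrogen: 5-fluoro-2-methoxyphenyl in place of furan-2-yl on a saturated chain carbon bound to an amine nitrogen. For the measured compounds named here, no measured pair shows this change on its own. Compound 3 already carries the same 5-fluoro-2-methoxybenzyl on another core and gives 2960 nM, level with compound 1. In this assay no change beyond the scatter is therefore expected, and the estimated step of a 1.1-fold higher number from compound 1 to compound 4 (0.05 log units; within the scatter) is small. Compound 4 is expected at 2700 nM (estimated range from 1300 nM to 5500 nM).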

Compound 4, half-maximal effective concentration in the HepG2 assay: 870 nM
Beside the measured number, compound 4's estimate is 3.1-fold (0.49 log units) above it; the whole stated range lies above it.
By their numbers in the HepG2 assay, from the lowest: compound 4; then compounds 1 and 3 (each within the scatter of the next); then compound 2.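

In the HepG2 assay, putting 5-fluoro-2-methoxyphenyl in place of furan-2-yl on a saturated chain carbon bound to an amine nitrogen gives a 2.8-fold lower number from compound 1 to compound 4 (0.44 log units; beyond the scatter), at 870 nM, and so provides the first single-change pair showing that this position affects the number on the core of compound 1. In a physicochemical assay for acid dissociation, compound 1 gives 9.47 and compound 4 gives 9.47. In the physicochemical assay the same exchange gives no change at the digits printed from compound 1 to compound 4 (within the scatter) and thus separates the two read-outs for this pair. No measurement shown here accounts for the step.

The compounds shown leave open whether the fluorine or the methoxy of the new group carries the step, and whether a plain phenyl or a cyclohexyl would do the same. They also leave open whether the step would persist with a longer chain.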